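Moving the Methyl on the Urea Aryl Group

A few compounds are considered here, and "the series" means these few. Any claim that something is new, unique, unknown or untested is made for them only; others in the source may bear on it.

The measured compounds, each with its result in a functional assay on HepG2 cells (Homo sapiens) for antiproliferative activity, read by MTT assay, with a stated time of 48 h; on this read-out lower numbers stand for stronger inhibition and higher numbers for weaker inhibition:
Compound 1 `CCOc1ccc(NC(=O)Nc2cccc(CNc3nccnc3Cl)c2)cc1` gives 7050 nM.
Compound 2 `O=C(Nc1cccc(CNc2nccnc2Cl)c1)Nc1ccc(Cl)cc1Br` gives 6720 nM.
Compound 3 `Cc1ccccc1NC(=O)Nc1cccc(CNc2nccnc2Cl)c1` gives 15300 nM.

Among these three, compound 1 stands second highest. Its nearest neighbour is compound 2, with a step of a 1.0-fold lower number from compound 1 to compound 2 (0.02 log units; within the scatter), so those two cannot be told apart. Compound 3 lies furthest away, with a 2.2-fold higher number from compound 1 to compound 3 (0.34 log units; beyond the scatter), a modest but real loss of inhibition when 2-methylphenyl replaces 4-ethoxyphenyl; the same direction appears in a 2.3-fold higher number from compound 2 to compound 3 (0.36 log units; beyond the scatter).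

Compound 4 `Cc1cccc(NC(=O)Nc2cccc(CNc3nccnc3Cl)c2)c1` is not yet measured. It differs from compound 1 in one place: 3-methylphenyl in place of 4-ethoxyphenyl on an amide-type nitrogen. Among the compounds with values here, the steps that bear on this are those into compound 3, since both show that a small methyl-bearing aryl ring in this position gives weaker inhibition than either 4-ethoxyphenyl or 2-bromo-4-chlorophenyl. Within the data shown here, compound 4 carries its methyl in a different position, and no measured pair tests that exact change, so the expected step for compound 4 is a modest weakening, a 1.4-fold higher number from compound 1 to compound 4 (0.15 log units; within the scatter). Compound 4 is therefore estimated at 10000 nM, expected to fall between 4500 nM and 22000 nM.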

Compound 4, half-maximal inhibitory concentration: 11200 nM
Compound 4: middle estimate off by 1.1-fold (0.05 log units), on the low side; the measured number falls inside the stated range.
By their numbers in this assay, from the lowest: compounds 2, 1, 4 and 3 (each within the scatter of the next, the first and the last beyond it).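

In this assay the methyl-bearing rings of compound 3 and compound 4 cannot be told apart (a 1.4-fold lower number from compound 3 to compound 4 (0.14 log units; within the scatter)), so 2-methylphenyl and 3-methylphenyl give no measurable difference at this amide-type nitrogen. The new compound also cannot be separated from the two with larger aryl groups (a 1.6-fold higher number from compound 1 to compound 4 (0.20 log units; within the scatter); a 1.7-fold higher number from compound 2 to compound 4 (0.22 log units; within the scatter)), even though compound 3 does stand apart from both of them, which leaves 3-methylphenyl overlapping every other group tested here rather than siding clearly with either the weaker or the stronger end. The data offer no measured explanation for how these compounds rank, and no independent information on what lies behind these numbers.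

The compounds shown leave open whether 4-methylphenyl, with the methyl on the ring position that carries the ethoxy group in compound 1, would behave like the other two methyl-bearing rings. They also leave open what happens when the aryl ring at this nitrogen carries an amine or a carboxylic acid, or gives way to a simple alkyl chain, since every group here is a substituted phenyl ring.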